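The compounds below may be only part of what the source reports. "The series", "measured", "known", "first", "only" and "open" are said of these compounds alone.

Going by the values given here, compound 2 `CCCCCCCc1cn(Cc2ccc(C#N)cc2)nn1` carries a heptyl chain on its triazole and, in an assay on isolated protein for inhibition of Aromatase (Homo sapiens), read by fluorescence and colorimetric assay, with a stated time of 30 min (on this read-out higher numbers stand for weaker inhibition and lower numbers for stronger inhibition), compound 2 gives 3070 nM, the lowest of the three numbers measured so far. Compound 3 `N#Cc1ccc(Cn2cc(C3CCCCC3)nn2)cc1` gives 10700 nM in this assay, and compound 1 `N#Cc1ccc(C(c2ccc(C#N)cc2)n2cc(COc3ccccc3)nn2)cc1` gives 11000 nM. Among the compounds with values here, the one step measured in a single place, a 3.5-fold higher number from compound 2 to compound 3 (0.54 log units; beyond the scatter), shows that trading the open chain for a ring costs potency. Compound 4 `N#Cc1ccc(Cn2cc(COc3ccccc3)nn2)cc1` is compound 2 with phenoxy in place of hexyl on a saturated chain carbon bound to an aromatic carbon. Within the data shown here, no measured step matches this change exactly, yet the ring-for-chain step from compound 2 to compound 3 points toward a weaker result, so a modest rise is expected, a 2.6-fold higher number from compound 2 to compound 4 (0.42 log units; beyond the scatter). Compound 4 is therefore estimated at 8000 nM, within a range from 3000 nM to 25000 nM.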

Compound 4, half-maximal inhibitory concentration: 6090 nM
For compound 4 the middle estimate is 1.3-fold (0.12 log units) above the measured one, within the range that was stated.
By their numbers in this assay, from the lowest: compounds 2, 4, 3 and 1 (each within the scatter of the next, the first and the last beyond it).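

In this assay, phenoxy in place of hexyl gives a 2.0-fold higher number from compound 2 to compound 4 (0.30 log units; within the scatter), so this ring-bearing group holds up where the cyclohexyl step, a 3.5-fold higher number from compound 2 to compound 3 (0.54 log units; beyond the scatter), did not. Hydrogen in place of 4-cyanophenyl gives a 1.8-fold lower number from compound 1 to compound 4 (0.26 log units; within the scatter), so this second aromatic group can go without a change beyond the scatter. No evidence is available to explain either result. The compounds shown leave open how an amine or a chain longer than heptyl would fare on the triazole.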